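Estimating Compound 4 in the Tail Flick Test

A few compounds are considered here, and "the series" means these few. Any claim that something is new, unique, unknown or untested is made for them only; others in the source may bear on it.

Compound 3 `N=C(N)NCCC[C@H](NC(=O)CN(c1ncnc2c1ncn2C1CCCCO1)C1CC1)C(=O)OCc1ccccc1` stands highest of the three measured numbers in a functional assay on the whole organism (Tail, strain ICR) with Mus musculus as the target, in the tail flick test, with a stated time of 120 min, at a dose of 25 umol/kg by the oral route (a higher number here means a stronger effect of the compound at the dose given, a lower number a weaker effect), giving 38.2%. Compound 1 `C[C@H](NC(=O)CN(c1ncnc2c1ncn2C1CCCCO1)C1CC1)C(=O)OCc1ccccc1` gives 25.3% and compound 2 `CC(C)(C)OC(=O)NCCCC[C@H](NC(=O)CN(c1ncnc2c1ncn2C1CCCCO1)C1CC1)C(=O)OCc1ccccc1` gives 28.4%. Compound 4 `CC(C)C[C@H](NC(=O)CN(c1ncnc2c1ncn2C1CCCCO1)C1CC1)C(=O)OCc1ccccc1` differs from compound 3 by a group of 3 heavy atoms (3 carbon; no ring) in place of a group of 6 heavy atoms (3 carbon, 3 nitrogen; no ring), on a saturated chain carbon, two bonds along the chain from an amide-type nitrogen and a carbonyl carbon. The measured step that bears most on this change is a number 12.9 percentage points higher from compound 1 to compound 3 (beyond the scatter); compound 1 carries hydrogen at that place. The other steps, a number 3.1 percentage points higher from compound 1 to compound 2 (within the scatter) and a number 9.8 percentage points higher from compound 2 to compound 3 (within the scatter), stayed within the scatter. Taking away the group present in compound 3 is therefore expected to lower the number, by roughly a number 11.2 percentage points lower from compound 3 to compound 4 (beyond the scatter). Compound 4 is thus expected to give about 27%, in a range from 17% to 37%.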

Compound 4, a percentage reported as activity, at one dose (the size of the read-out at that dose, not a potency): 12.8%
Compound 4: the middle estimate sits 14.2 percentage points above what was measured, outside the stated range (below it).
By their numbers in this assay, from the lowest: compound 4; then compounds 1, 2 and 3 (each within the scatter of the next, the first and the last beyond it).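

In this assay isopropyl, on a saturated chain carbon two bonds along the chain from an amide-type nitrogen and a carbonyl carbon, gives the lowest number of the four compounds, with a number 25.4 percentage points lower from compound 3 to compound 4 (beyond the scatter) and a number 15.6 percentage points lower from compound 2 to compound 4 (beyond the scatter) as well as a number 12.5 percentage points lower from compound 1 to compound 4 (beyond the scatter) beyond the scatter. This last step shows that a group at this place can lower the number relative to hydrogen, which neither earlier group had done. Nothing available explains this drop. Going by these compounds, whether an amine, a carboxylic acid or a longer unbranched carbon chain here would fall nearer compound 3 or compound 4 stays open.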